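Replacing the dichlorophenyl of compound 1 on the shared core

The source may hold more compounds than are shown below. What is called first, only, known or untested is meant among the compounds shown, and "the series" means these compounds.

Compound 1 `COC(=O)C1=C(C)N=C(C)/C(=C(\O)OC)C1c1c(Cl)cccc1Cl` — 1.91 nM
Compound 3 `COC(=O)C1=C(C)N=C(C)/C(=C(\O)OC)C1c1ccccc1I` — 46.8 nM
Compound 2 `COC(=O)C1=C(C)N=C(C)/C(=C(\O)OC)C1c1cccc(OC(=O)c2ccccc2)c1` — 6310 nM

In a functional assay (muscle tissue) with Cavia porcellus as the target (a higher number here means that more compound is needed for the effect, a lower number that less compound is needed), compound 1 gives the lowest of the three numbers. Compound 3 stands nearest, with a 25-fold higher number from compound 1 to compound 3 (1.39 log units; beyond the scatter); compound 2 stands furthest, and its value is far higher than that of compound 1.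

Compound 4 `COC(=O)C1=C(C)N=C(C)/C(=C(\O)OC)C1c1cccc(C)c1` is not yet measured. It differs from compound 1 as follows: 3-methylphenyl in place of 2,6-dichlorophenyl on a saturated ring carbon. Among the measured compounds shown here, the only measured step that bears on this is the one from compound 1 to compound 3, where the same position was changed and the number rose by a 25-fold higher number from compound 1 to compound 3 (1.39 log units; beyond the scatter). A rise beyond the scatter is therefore expected for compound 4 as well, of roughly that size or larger, a 79-fold higher number from compound 1 to compound 4 (1.90 log units; beyond the scatter). Compound 4 is estimated at 150 nM, within 20 nM to 1500 nM.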

Compound 4, half-maximal effective concentration: 110 nM
For compound 4 the middle estimate is 1.4-fold (0.13 log units) above the measured one; the range from low to high includes it.
By their numbers in this assay, from the lowest: compound 1; then compound 3; then compound 4; then compound 2.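

In this assay, 3-methylphenyl on this saturated ring carbon brings a large rise (a 58-fold higher number from compound 1 to compound 4 (1.76 log units; beyond the scatter)), so a second replacement without chlorine also falls well short of the low number of compound 1. The gap to 2-iodophenyl is only modest (a 2.4-fold higher number from compound 3 to compound 4 (0.37 log units; beyond the scatter)), whereas methyl in place of benzoyloxy on an aromatic carbon has a far larger effect (a 57-fold lower number from compound 2 to compound 4 (1.76 log units; beyond the scatter)). Nothing available here explains these differences. The compounds shown leave open how an amine or a carboxylic acid on that aromatic carbon would compare with methyl or benzoyloxy.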